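Ester variation and stability in phosphate buffer

The source may report more compounds than this note shows. Statements on the series, on what has been measured and on what is new or still open speak of the compounds shown alone.

Compound 1 `CCOC(=O)C1=C(S[C@@H]2CN[C@H](C(=O)Nc3cccc(C(=O)O)c3)C2)[C@H](C)[C@@H]2[C@@H]([C@@H](C)O)C(=O)N12` and compound 2 `C[C@@H](O)[C@H]1C(=O)N2C(C(=O)OCOC(=O)OC(C)(C)C)=C(S[C@@H]3CN[C@H](C(=O)Nc4cccc(C(=O)O)c4)C3)[C@H](C)[C@H]12` share one core and differ only in the ester group. In a physicochemical assay for metabolic stability, read by LC-MS, in phosphate buffer, with a stated time of 3 h, at pH 7.4, tested at 50 uM (on this read-out higher numbers stand for a more stable compound and lower numbers for a less stable compound), compound 1 gives > 95%, which is a limit of the assay rather than a number. In this assay compound 2 gives > 95%, again a limit and not a number. The step that the two limits leave unreadable from compound 1 to compound 2 cannot be read because the limit of > 95% in this assay, at which 2 of the 2 values shown sit, places both values shown at that limit. Compound 2 therefore stands at the limit of the read-out, with no number separating it from compound 1. Compound 3 `CC(C)OC(=O)C1=C(S[C@@H]2CN[C@H](C(=O)Nc3cccc(C(=O)O)c3)C2)[C@H](C)[C@@H]2[C@@H]([C@@H](C)O)C(=O)N12` differs from compound 2 by isopropyl in place of ((tert-butoxycarbonyl)oxy)methyl on an oxygen next to a carbonyl group. For the measured compounds named here, only the step from compound 1 to compound 2 bears on this change, and it gave no readable size, so the expectation rests on both measured compounds sitting at the limit. The step that the limit leaves unreadable from compound 2 to compound 3 is expected to stay within the scatter, with compound 3 most likely reported at the limit once more. Compound 3 is estimated at 96%, between 88% and 100%.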

Compound 3, percent of the compound remaining: > 95%
Compound 3 gave a limit, no number; the forecaster's own chance of this, stated with the estimate: 80%; the middle value lies beyond the limit too.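

For the compounds shown here, no step between compound 1, compound 2 and compound 3 can be read in this assay, because all three values are limits of the assay rather than numbers: the limit of > 95% in this assay, at which 3 of the 3 values shown sit.

The compounds shown leave open whether the ester groups on the shared core differ at all in this assay, and how large any such difference would be.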